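Swapping methoxy for hydroxy on a largely inactive compound

The compounds below may be only part of what the source reports. "The series", "measured", "known", "first", "only" and "open" are said of these compounds alone.

Compound 1 `C/C=C(\C)C(=O)O[C@@H]1[C@@H]2OC[C@]3(C)[C@H](OC(C)=O)C[C@H](OC(C)=O)[C@@](C)([C@@H]23)[C@H]2C[C@H](OC)O[C@H]3C[C@@H](C4=CCOC4=O)C(C)=C3[C@]12C` gives > 100000 nM (a limit)
Compound 2 `C/C=C(\C)C(=O)O[C@@H]1[C@@H]2OC[C@]3(C)[C@H](OC(C)=O)C[C@H](O)[C@@](C)([C@@H]23)[C@H]2C[C@H](OC)O[C@H]3C[C@@H](C4=CCOC4=O)C(C)=C3[C@]12C` gives > 100000 nM (a limit)
Compound 3 `C/C=C(\C)C(=O)O[C@@H]1[C@@H]2OC[C@]3(C)[C@H](OC(=O)/C(C)=C/C)C[C@H](O)[C@@](C)([C@@H]23)[C@H]2C[C@H](OC)O[C@H]3C[C@@H](C4=CCOC4=O)C(C)=C3[C@]12C` gives 13000 nM (a number)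

All three values come from a functional assay on HeLa cells (Homo sapiens) for cytotoxicity, read by MTT assay (on this read-out lower numbers stand for stronger inhibition and higher numbers for weaker inhibition), as the read-out. Compound 2 sits, as a limit and not a number, at the limit of > 100000 nM in this assay, at which 2 of the 3 values shown sit, here. Compound 4 `C/C=C(\C)C(=O)O[C@@H]1[C@@H]2OC[C@]3(C)[C@H](OC(C)=O)C[C@H](O)[C@@](C)([C@@H]23)[C@H]2C[C@H](O)O[C@H]3C[C@@H](C4=CCOC4=O)C(C)=C3[C@]12C` differs from it by hydrogen in place of methyl on an oxygen on a saturated carbon in one place, methoxy to hydroxy. The nearest measured change, also hydrogen arriving on an oxygen, is a step that the two limits leave unreadable from compound 1 to compound 2 and offers no size to carry over. The other is an at least 7.6-fold lower number from compound 2 to compound 3 (0.88 log units; beyond the scatter) on a carbonyl carbon, a different change. So no step beyond the scatter is expected, and the estimated step is a number no higher from compound 2 to compound 4 (the limit leaves the size open) in this case. Compound 4 is estimated at 100000 nM with a range of 30000 nM to 300000 nM and may well read only as a limit.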

Compound 4, half-maximal inhibitory concentration: 32000 nM
For compound 4 the middle estimate is 3.1-fold (0.49 log units) above the measured one, within the range that was stated.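

Swapping methoxy for hydroxy at this position gives an at least 3.1-fold lower number from compound 2 to compound 4 (0.49 log units; beyond the scatter), so this oxygen on a saturated carbon does affect the read-out. The earlier step that brought hydrogen onto an oxygen could not be read, whereas this one yields a real number. Its exact size stays open, as compound 2 has only a limit: the limit of > 100000 nM in this assay, at which 2 of the 4 values shown sit.

The compounds shown do not tell how an ethoxy group, a longer chain on this oxygen, or an amine in its place would read. They also leave open whether the same swap would matter on other esters of the shared core.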